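Butyl for Methoxy: Expecting a Cytotoxicity Value

The source may hold more compounds than are shown below. What is called first, only, known or untested is meant among the compounds shown, and "the series" means these compounds.

The study concerns a small set of compounds built on one shared core and tested in a functional assay on HeLa cells (Homo sapiens) for cytotoxicity, read by WST assay, with a stated time of 48 h; a higher number here means that more compound is needed for the effect, a lower number that less compound is needed. Among the measured compounds shown here, compound 1 `O=C1OC[C@H](Cc2ccccc2)[C@H]1Cc1ccc(Cl)c(Cl)c1` is the only member with a reported number: in this assay compound 1 gives 26000 nM. Compound 2 `COc1ccc(C[C@H]2COC(=O)[C@@H]2Cc2ccc(Cl)c(Cl)c2)cc1` was submitted to the same test, but in this assay compound 2 gives "not determined" (no result reported), so compound 2 stands nowhere on the numbers shown; there is no value for it. Compound 3 `CCCCc1ccc(C[C@H]2COC(=O)[C@@H]2Cc2ccc(Cl)c(Cl)c2)cc1` differs from compound 2 in a single place: butyl in place of methoxy on an aromatic carbon. For the measured compounds named here, no step between measured compounds is known, and the only anchor is the value of compound 1. For the change from compound 2 to compound 3 in this assay, the account expects a step of modest size, not clearly beyond the scatter, with the direction left open; the data give no ground to favor a gain or a loss. Resting on compound 1 and its 26000 nM, compound 3 is expected to give about 15000 nM in this assay, with a plausible span from 3000 nM to 60000 nM.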

Compound 3, half-maximal effective concentration: 27000 nM
The estimate for compound 3 lay 1.8-fold (0.26 log units) below the measured number, within the range that was stated.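

In this assay, among the compounds shown here, butyl in place of hydrogen on an aromatic carbon, para to a large group, gives a 1.0-fold higher number from compound 1 to compound 3 (0.02 log units; within the scatter), so this is the first reading at this position, and it does not separate the substituted compound from the unsubstituted one. For the compounds shown here, a butyl chain at this carbon therefore leaves the number where the core of compound 1 already stood, whereas the earlier compounds offered no comparison at this position at all; the step from methoxy to butyl cannot be read, since compound 2 has no reported result. Nothing available here bears on why butyl leaves the number in this assay within the scatter.

The compounds shown leave open what methoxy itself does at this carbon, and so whether that group would sit with hydrogen and butyl or apart from them. They also leave open whether an amine, a carboxylic acid or a chain longer than butyl at the same place would give a step beyond the scatter in this assay.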